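The compounds below may be only part of what the source reports. "The series", "measured", "known", "first", "only" and "open" are said of these compounds alone.

Compounds measured so far: compound 1 `ClCc1cccc(Cn2cnc3c(Cl)ncnc32)c1`, 5750 nM; compound 2 `ClCc1ccc(Cn2cnc3nc(Cl)nc(Cl)c32)cc1`, 2510 nM; compound 3 `ClCc1cccc(Cn2cnc3c(Cl)nc(Cl)nc32)c1`, 6450 nM.

In a functional assay on OVCAR-3 cells (Homo sapiens) for cytotoxicity, read by sulforhodamine B assay, with a stated time of 48 h (on this read-out higher numbers stand for lower toxicity in this test and lower numbers for higher toxicity in this test), compound 1 gives 5750 nM, compound 2 gives 2510 nM and compound 3 gives 6450 nM. Compound 2 has the lowest number of the three; its distance to compound 1 and to compound 3 is in each case beyond the scatter. The difference between the core of compound 2 and the core of compound 3 is not broken down here.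

Compound 3 and compound 1 differ in one place, (hydrogen in place of chloro on an aromatic carbon), and that change gave a 1.1-fold lower number from compound 3 to compound 1 (0.05 log units; within the scatter).

Compound 4 `ClCc1ccc(Cn2cnc3ncnc(Cl)c32)cc1` has not yet been measured in this assay. It differs from compound 2 by the same change, (hydrogen in place of chloro on an aromatic carbon). Since the step from compound 3 to compound 1 was a 1.1-fold lower number from compound 3 to compound 1 (0.05 log units; within the scatter), the step from compound 2 to compound 4 is expected to be of about the same size, a 1.1-fold lower number from compound 2 to compound 4 (0.04 log units; within the scatter). On that basis compound 4 is estimated at 2300 nM in this assay, with a likely range from 1200 nM to 4600 nM.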

Compound 4, concentration lethal to 50% of the cells: 6300 nM
Beside the measured number, compound 4's estimate is 2.7-fold (0.44 log units) below it; measured number outside the range, above it.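

In this assay, putting hydrogen in place of the chloro group on the aromatic carbon between two ring nitrogen atoms gave a 2.5-fold higher number from compound 2 to compound 4 (0.40 log units; beyond the scatter), which means lower toxicity in this test. Within the data shown here, the same change did not carry over at one size from one core to the other: the same change on two cores in this assay, a 1.1-fold lower number (0.05 log units; within the scatter) from compound 3 to compound 1 and a 2.5-fold higher number (0.40 log units; beyond the scatter) from compound 2 to compound 4, 2.8-fold (0.45 log units) apart, beyond the scatter of two such steps This shows that, in this series, the step seen on one core cannot be taken as the step on another, but with only one pair per core it does not show why the two differ or what the change would do on any further core.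

The compounds shown leave open what an amine or a methoxy group would do in place of the chloro group on that carbon, on either core. They also leave open what a hydroxymethyl group would do in place of the chloromethyl group that every compound shown carries.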